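Fluoro on the Phenyl Ring of a Piperidinyl Oxazolopyridine

The source may hold more compounds than are shown below. What is called first, only, known or untested is meant among the compounds shown, and "the series" means these compounds.

Two members of the series have been examined in an assay on isolated protein for inhibition of Amine oxidase [flavin-containing] B (Homo sapiens), read by fluorescence, with a stated time of 1 h; on this read-out higher numbers stand for weaker inhibition and lower numbers for stronger inhibition. Compound 1 `c1ccc(-c2nc3ccc(N4CCCCCC4)nc3o2)cc1` bears an azepane ring on the shared core; in this assay compound 1 is recorded as "not determined" (no result reported), so no number exists for it. Among the measured compounds shown here, compound 2 `c1ccc(-c2nc3ccc(N4CCCCC4)nc3o2)cc1` carries a piperidine ring in the same position, and in this assay compound 2 gives 1370 nM, which is the only number in hand for the series, so there is nothing to rank it against.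

Compound 3 `Fc1cccc(-c2nc3ccc(N4CCCCC4)nc3o2)c1` is the next step from compound 2. The change is fluoro in place of hydrogen on an aromatic carbon, on an aromatic carbon of a six-membered aromatic ring of carbon only, meta to a large group. For the measured compounds named here, no step between two measured compounds is available to calibrate this change, so the estimated step is a small one, a 1.5-fold lower number from compound 2 to compound 3 (0.18 log units; within the scatter), towards stronger inhibition and not clearly beyond the scatter. Compound 3 is therefore expected to give 900 nM, within 300 nM to 2700 nM.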

Compound 3, half-maximal inhibitory concentration: 272 nM
Beside the measured number, compound 3's estimate is 3.3-fold (0.52 log units) above it; the measured number lies below the stated range.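

Replacing phenyl with 3-fluorophenyl gives a 5.0-fold lower number from compound 2 to compound 3 (0.70 log units; beyond the scatter) in this assay, so this aromatic ring is not indifferent to substitution. Among the compounds shown here, a single fluoro at this place, meta to a large group, moves the number beyond the scatter, and this is the first step that can be read. Nothing in hand accounts for the size of the step.

From the compounds shown here alone, with one pair, it remains open whether the gain belongs to fluoro itself or would also appear with chloro, methoxy or nitrile at the same place, and whether fluoro at other carbons of the ring would do the same. Going by these compounds, it is also open whether the step carries over to the azepane of compound 1, which has no number to compare.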